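The source may hold more compounds than are shown below. What is called first, only, known or untested is meant among the compounds shown, and "the series" means these compounds.

The measured compounds:
compound 1, `O=C1N[C@H]2[C@H](CS[C@H]2CCCCCc2cn(Cc3cccc(O)c3)nn2)N1`: > 16000 nM
compound 2, `COc1cccc(Cn2cc(CCCCC[C@@H]3SC[C@@H]4NC(=O)N[C@@H]43)nn2)c1`: > 16000 nM
compound 3, `O=C1N[C@H]2[C@H](CS[C@H]2CCCCCc2cn(Cc3cccc(F)c3)nn2)N1`: > 16000 nM

In an assay on isolated protein for inhibition of biotin--protein ligase (Homo sapiens), read by scintillation counting, with a stated time of 10 min (on this read-out lower numbers stand for stronger inhibition and higher numbers for weaker inhibition), compound 1 reaches only a limit of the assay, > 16000 nM. Compound 2 also sits at a limit. Compound 3 likewise sits at a limit. Among the compounds with values here, all three values share (the limit of > 16000 nM in this assay, at which 3 of the 3 values shown sit), so compound 1 stands nowhere in particular among them: no compound can be placed above or below another. The steps a step that the two limits leave unreadable from compound 1 to compound 2, a step that the two limits leave unreadable from compound 1 to compound 3 and a step that the two limits leave unreadable from compound 2 to compound 3 are accordingly unreadable in both size and direction.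

Compound 4, `O=C1N[C@H]2[C@H](CS[C@H]2CCCCCc2cn(Cc3ccccc3Cl)nn2)N1`, is not yet measured. Against compound 1 it shows (2-chlorophenyl in place of 3-hydroxyphenyl on a saturated chain carbon bound to an aromatic nitrogen). Within the data shown here, none of the measured steps covers this exchange; the closest, hydroxy for fluoro, a step that the two limits leave unreadable from compound 1 to compound 3, yields no size. With three limits and no readable step, compound 4 is expected in this assay to give a further limit or a value close to it, a step that the limit leaves unreadable from compound 1 to compound 4 estimated from compound 1. Compound 4 is estimated at 20000 nM, within a range of 8000 nM to 50000 nM.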

Compound 4, inhibition constant: > 16000 nM
Compound 4: no number, only a limit; the forecaster's own chance of this, stated with the estimate: 80%; the middle value does not contradict the limit.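

In this assay compound 4 gives > 16000 nM, which is a limit and not a number. Within the data shown here, no step between compound 4 and compound 1, compound 2 or compound 3 can be read, since all four stand at one limit: the limit of > 16000 nM in this assay, at which 4 of the 4 values shown sit. The compounds shown leave open whether any of these benzyl groups gives a measurable inhibition constant.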